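The source may report more compounds than this note shows. Statements on the series, on what has been measured and on what is new or still open speak of the compounds shown alone.

Working notes on the series. Compound 1 `O[C@H](COCCOC[C@@H](O)Cc1cn(-c2cccs2)nn1)Cc1ccc(-c2ccccc2)cc1` gives 33400 nM in a functional assay on SGC-7901 cells (Homo sapiens) for inhibition, read by MTT assay, with a stated time of 72 h; a higher number here means a weaker inhibitor of growth, a lower number a stronger inhibitor of growth. Going by the values given here, compound 2 `O=c1[nH]c2ccc(-n3cc(C[C@H](O)COCCOC[C@@H](O)Cc4ccc(-c5ccccc5)cc4)nn3)cc2s1` gives 10500 nM in this assay, the lowest of the two numbers so far; the only measured step, a 3.2-fold lower number from compound 1 to compound 2 (0.50 log units; beyond the scatter), came with the larger bicyclic group on the triazole nitrogen in place of the thiophene ring. Compound 3 `O[C@H](COCCOC[C@@H](O)Cc1cn(-c2cncc3ccccc23)nn1)Cc1ccc(-c2ccccc2)cc1` is not yet measured. It differs from compound 2 by a group of 10 heavy atoms (9 carbon, 1 nitrogen; one six-membered aromatic ring of carbon only, one six-membered aromatic ring with 1 hetero atom) in place of a group of 10 heavy atoms (7 carbon, 1 nitrogen, 1 oxygen, 1 sulfur; one five-membered aromatic ring with 2 hetero atoms, one six-membered aromatic ring of carbon only), on an aromatic nitrogen. Among the compounds with values here, no measured step bears directly on an exchange of one bicyclic group for another on this nitrogen; the step from compound 1 to compound 2 only shows that the group on that nitrogen moves the number by a modest amount. Compound 3 carries a group of the same size as that of compound 2 but without the donor, so the expected value lies between those of compound 1 and compound 2, and compound 3 is estimated at 18000 nM (range 7000 nM to 45000 nM). This estimate means a step of a 1.7-fold higher number from compound 2 to compound 3 (0.23 log units; within the scatter), which is expected to stay near the scatter.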

Compound 3, concentration for 50% growth inhibition: 29300 nM
For compound 3 the middle estimate is 1.6-fold (0.21 log units) below the measured one, and the stated range covers the measured number.
By their numbers in this assay, from the lowest: compound 2; then compounds 3 and 1 (each within the scatter of the next).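

At this aromatic nitrogen, the size of the group does not decide the outcome: in this assay, with the count of 10 heavy atoms unchanged, isoquinolin-4-yl in place of the group of compound 2 gives a 2.8-fold higher number from compound 2 to compound 3 (0.45 log units; beyond the scatter). Isoquinolin-4-yl in place of the smaller thiophen-2-yl gives a 1.1-fold lower number from compound 1 to compound 3 (0.06 log units; within the scatter), so the added ring of isoquinolin-4-yl brings no gain here, and among these three compounds only the group of compound 2 stands apart. No measurement on hand accounts for this difference.

From the compounds shown here alone, the exchange in compound 3 removes the hydrogen-bond donor but also changes the ring atoms, so the part of the group of compound 2 that matters stays open. Also open, going by these compounds, is how a phenyl ring carrying an amine or a carboxylic acid would read at this nitrogen.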